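This account rests on a few compounds, and the source may have more. Where it says the series, first, only, none or still open, it means among the compounds named here.

Measured in a functional assay on MCF7 cells (Homo sapiens) for antiproliferative activity, read by MTT assay, with a stated time of 48 h; a higher number here means a weaker inhibitor, a lower number a stronger inhibitor:
compound 1 `C#CCOc1ccc(/C=C/C(C)=O)cc1OC`: 65400 nM
compound 2 `COc1cc(/C=C/C(C)=O)ccc1OCc1cn(-c2ccccc2CO)nn1`: 65800 nM
compound 3 `COc1cc(/C=C/C(C)=O)ccc1OCc1cn(-c2ccc(/N=N/c3ccccc3)cc2)nn1`: 75900 nM

Compound 2 gives 65800 nM, second highest of the three numbers, yet within the scatter of both compound 1 and compound 3. Compound 4 `COc1cc(/C=C/C(C)=O)ccc1OCc1cn(-c2ccccc2OC)nn1` differs from compound 2 by methoxy in place of hydroxymethyl on an aromatic carbon, with methoxy in place of hydroxymethyl on an aromatic carbon, ortho to a large group. Within the data shown here, no measured pair differs in one place, so the data show no direct precedent for this change. Even so, compound 3, at 75900 nM, stays within the scatter of compound 2 despite its different substituent, so no shift beyond the scatter is expected in this assay, in either direction. The expected change is a 1.1-fold lower number from compound 2 to compound 4 (0.03 log units; within the scatter). For compound 4 the estimated value is 62000 nM, with an expected range of 32000 nM to 100000 nM.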

Compound 4, half-maximal inhibitory concentration: 29100 nM
Compound 4: the middle estimate sits 2.1-fold (0.33 log units) above what was measured; measured number below the stated range.
By their numbers in this assay, from the lowest: compound 4; then compounds 1, 2 and 3 (each within the scatter of the next).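

In this assay, among these compounds, methoxy in place of hydroxymethyl on an aromatic carbon, ortho to a large group, gives a 2.3-fold lower number from compound 2 to compound 4 (0.35 log units; beyond the scatter) and so shows that this position responds to a change of substituent, which the earlier compounds, none differing in one place, could not show. The two groups match in heavy atoms, and they differ in that hydroxymethyl counts a hydrogen-bond donor and methoxy none. Nothing measured here accounts for the step. As far as these compounds go, whether ethoxy, an amine or a carboxylic acid on this carbon would move the number the same way stays open.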